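This account rests on a few compounds, and the source may have more. Where it says the series, first, only, none or still open, it means among the compounds named here.

Measured compounds:
compound 1 `[O-][S+](Cc1ccc(Cl)s1)C(c1ccccc1)c1ccccc1`, 12800 nM in an assay on HEK293 cells for inhibition of sodium-dependent dopamine transporter (Homo sapiens), read by scintillation counting, with stated times of 5 min and 1 min; a lower number here means a stronger inhibitor, a higher number a weaker inhibitor
compound 2 `Cc1scc(C[S+]([O-])C(c2ccccc2)c2ccccc2)c1C`, 284000 nM in this assay
compound 3 `[O-][S+](Cc1ccncc1)C(c1ccccc1)c1ccccc1`, 63500 nM in this assay

Compound 3 stands second highest of the three numbers; compound 1 sits lower, compound 2 higher. Compound 4 `O=c1[nH]nc(C[S+]([O-])C(c2ccccc2)c2ccccc2)s1` is not yet measured. It differs from compound 3 by a group of 6 heavy atoms (2 carbon, 2 nitrogen, 1 oxygen, 1 sulfur; one five-membered aromatic ring with 3 hetero atoms) in place of a group of 6 heavy atoms (5 carbon, 1 nitrogen; one six-membered aromatic ring with 1 hetero atom), on a saturated chain carbon bound to a sulfur.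

Going by the values given here, the steps that bear on this are the ones that swap the aromatic group at the same position: a 5.0-fold higher number from compound 1 to compound 3 (0.70 log units; beyond the scatter), a 4.5-fold lower number from compound 2 to compound 3 (0.65 log units; beyond the scatter) and a 22-fold higher number from compound 1 to compound 2 (1.35 log units; beyond the scatter). Among the compounds with values here, every such swap so far moved this assay beyond the scatter, by modest to large amounts, with no step small. The new ring with its donor and three acceptors is unlike any group tried, so the direction is open; a step of a 1.9-fold higher number from compound 3 to compound 4 (0.28 log units; within the scatter) toward a higher number is expected, with wide uncertainty. Compound 4 is estimated at 120000 nM, between 30000 nM and 500000 nM.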

Compound 4, half-maximal inhibitory concentration: 38100 nM
Estimate against measurement, compound 4: 3.1-fold (0.50 log units) above; the range from low to high includes it.
By their numbers in this assay, from the lowest: compound 1; then compounds 4 and 3 (each within the scatter of the next); then compound 2.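

In this assay, going by these compounds alone, the move a 1.7-fold lower number from compound 3 to compound 4 (0.22 log units; within the scatter) is the first ring swap on this saturated chain carbon bound to a sulfur to stay within the scatter, so pyridin-4-yl and the five-membered aromatic ring with 3 hetero atoms cannot be told apart here. The step of a 3.0-fold higher number from compound 1 to compound 4 (0.47 log units; beyond the scatter) leaves the 5-chlorothiophen-2-yl group ahead, and the step of a 7.5-fold lower number from compound 2 to compound 4 (0.87 log units; beyond the scatter) sets the new ring clear of the 4,5-dimethylthiophen-3-yl group.

Going by these compounds, whether a plain phenyl, a carboxylic acid or an amine at this carbon would match compound 1 stays open. Nothing measured here accounts for these differences.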